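This account rests on a few compounds, and the source may have more. Where it says the series, first, only, none or still open, it means among the compounds named here.

Among the measured compounds shown here, compound 2 `CCNC(=N)c1cnc(N2CCN(C3CCN(Cc4ccc(Cl)cc4)CC3)[C@@H](C)C2)c(Cl)c1` gives 83 nM in a functional assay for antagonist activity at C-X-C chemokine receptor type 3 (Homo sapiens); on this read-out lower numbers stand for stronger inhibition and higher numbers for weaker inhibition; compound 1 `C[C@H]1CN(c2ncc(C(=N)N)cc2Cl)CCN1C1CCN(Cc2ccc(Cl)cc2)CC1` gives 80 nM, and the step of a 1.0-fold higher number from compound 1 to compound 2 (0.02 log units; within the scatter) lies within the scatter, so compound 2 stands level with the only other measured compound. Compound 3 `C[C@H]1CN(c2ncc(C(=O)NCC3CCCCC3)cc2Cl)CCN1C1CCN(Cc2ccc(Cl)cc2)CC1` carries a group of 10 heavy atoms (8 carbon, 1 nitrogen, 1 oxygen; one six-membered non-aromatic ring of carbon only) in place of a group of 5 heavy atoms (3 carbon, 2 nitrogen; no ring), on an aromatic carbon. For the measured compounds named here, the sole measured step, a 1.0-fold higher number from compound 1 to compound 2 (0.02 log units; within the scatter), adds an ethyl to an amine nitrogen and leaves the rest untouched; it does not bear on exchanging the whole group, and no other measured step does. The step from compound 2 is therefore expected as a 3.6-fold higher number from compound 2 to compound 3 (0.56 log units; beyond the scatter), more likely toward a higher number. Compound 3 is expected at 300 nM, range 60 nM to 2000 nM.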

Compound 3, half-maximal inhibitory concentration: 2.4 nM
The estimate for compound 3 lay 130-fold (2.10 log units) above the measured number; the whole stated range lies above it.
By their numbers in this assay, from the lowest: compound 3; then compounds 1 and 2 (each within the scatter of the next).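

On an aromatic carbon two atoms from the ring nitrogen, the (cyclohexylmethyl)carbamoyl group gives a 35-fold lower number from compound 2 to compound 3 (1.54 log units; beyond the scatter) in this assay and a 33-fold lower number from compound 1 to compound 3 (1.52 log units; beyond the scatter) on the same read-out. Exchanging the whole group therefore moves the number strongly, whereas the earlier ethyl step on the amine nitrogen (a 1.0-fold higher number from compound 1 to compound 2 (0.02 log units; within the scatter)) did not, and this position accepts the larger group with a ring. No measured evidence accounts for the gain.

On these data alone, whether it depends on the cyclohexane ring, the carbonyl or the linking methylene remains open. A phenyl ring or a plain ethyl amide at this carbon would help to separate these.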